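Methylsulfonyl for cyano on the fluorinated aryl

The source may report more compounds than this note shows. Statements on the series, on what has been measured and on what is new or still open speak of the compounds shown alone.

Compound 3 `CC(C)OC(=O)N1CCC(Oc2ncnc3c2CCN3c2ccc(C#N)c(F)c2)CC1` gives 121% in a functional assay on CHO-K1 cells with Glucose-dependent insulinotropic receptor (Homo sapiens) as the target, read by a luciferase reporter, with a stated time of 5 h (on this read-out higher numbers stand for larger maximal responses and lower numbers for smaller maximal responses), the second highest of the three numbers. Compound 2 `CC(C)OC(=O)N1CCC(Oc2ncnc3c2CCN3c2ccc(S(C)(=O)=O)cn2)CC1` gives 111% in this assay, and the two lie within the scatter of each other: a number 10 percentage points higher from compound 2 to compound 3 (within the scatter). Compound 3 stands well below compound 1 `CC(C)OC(=O)N1CCC(Oc2ncnc3c2CCN3c2ccc(S(C)(=O)=O)cc2)CC1` with 154% (a number 33 percentage points lower from compound 1 to compound 3 (beyond the scatter)). Compound 4 `CC(C)OC(=O)N1CCC(Oc2ncnc3c2CCN3c2ccc(S(C)(=O)=O)c(F)c2)CC1` is not yet measured; it differs from compound 3 by methylsulfonyl in place of cyano on an aromatic carbon. Among the measured compounds shown here, the step that bears on this is the one from compound 1 to compound 3, where the methylsulfonyl group left and a cyano group with a fluoro group entered: a number 33 percentage points lower from compound 1 to compound 3 (beyond the scatter). Compound 4 keeps the fluoro group of compound 3 but brings back the methylsulfonyl group of compound 1, so part of that loss is expected to be recovered, an upward step a number 19 percentage points higher from compound 3 to compound 4 (beyond the scatter). Compound 4 is therefore estimated at 140%, within 115% to 165%.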

Compound 4, largest response reached (reported as percent of maximum), in percent of the reference or control that the assay uses: 109%
Beside the measured number, compound 4's estimate is 31 percentage points above it; the measured number lies below the stated range.
By their numbers in this assay, from the lowest: compounds 4, 2 and 3 (each within the scatter of the next, the first and the last beyond it); then compound 1.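

With a fluoro group ortho to it, methylsulfonyl does not outdo cyano in the para position, giving a number 12 percentage points lower from compound 3 to compound 4 (beyond the scatter), and the same fluoro group on the methylsulfonylphenyl of compound 1 costs most of the response, giving a number 45 percentage points lower from compound 1 to compound 4 (beyond the scatter). The fluorinated methylsulfonylphenyl and the methylsulfonylpyridinyl groups cannot be told apart here, with a number 2 percentage points lower from compound 2 to compound 4 (within the scatter). Nothing available explains these steps.

As far as these compounds go, whether fluoro costs as much alongside cyano stays open, without a partner of compound 3 lacking fluoro. Chloro or methoxy in place of fluoro also remains untested in these notes.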